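Opening the chain end: an amino chain on the shared core

The source may hold more compounds than are shown below. What is called first, only, known or untested is meant among the compounds shown, and "the series" means these compounds.

Measured in a functional assay on HCT-116 cells (Homo sapiens) for cytotoxicity, read by MTT assay, with a stated time of 72 h; a lower number here means a stronger inhibitor, a higher number a weaker inhibitor:
Compound 1 `O=C(NCc1ccc(F)cc1)c1nc(Br)c2cccnc2c1NCCO`: > 20000 nM
Compound 2 `COC(=O)CNc1c(C(=O)NCc2ccc(F)cc2)nc(Br)c2cccnc12`: > 10000 nM

Compound 2 has no number in this assay, only the limit > 10000 nM. Compound 1 likewise gives only a limit, > 20000 nM. No numerical value is therefore available for either compound.

Compound 3 `NCCCCCCNc1c(C(=O)NCc2ccc(F)cc2)nc(Br)c2cccnc12` keeps the shared core and alters the same chain: 5-aminopentyl in place of methoxycarbonyl on a saturated chain carbon bound to a nitrogen on an aromatic ring. For the measured compounds named here, the one measured step that bears on this change is a step that the two limits leave unreadable from compound 1 to compound 2, so it offers no size to carry over. The expectation therefore rests on the structural change alone, and it is a tentative one: a modest move towards stronger inhibition in this assay. The expected step is an at least 1.6-fold lower number from compound 2 to compound 3 (0.22 log units; that floor lies within the scatter), though a further limit would be no surprise. For compound 3 the estimate is 6000 nM, with an expected range of 1500 nM to 20000 nM.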

Compound 3, half-maximal inhibitory concentration: > 10000 nM
Compound 3: no number, only a limit; the forecaster's own chance of this, stated with the estimate: 35%; middle value at least 1.6-fold (0.22 log units) from the limit.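

In this assay compound 3 gives only a limit, > 10000 nM, not a number. For the compounds shown here, compound 1 and compound 2 also give only limits, so no step among the three can be read. The compounds shown leave open whether any of these chains on the shared core reaches a measurable value in this assay.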